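This account rests on a few compounds, and the source may have more. Where it says the series, first, only, none or still open, it means among the compounds named here.

Measured so far:
compound 1, `CCOc1ccc(NC(=O)N/N=C(\C)c2ccccc2O)cc1` — a functional assay on the whole organism with Mus musculus as the target, in the maximal electroshock model, with a stated time of 0.5 h; on this read-out higher numbers stand for an effect only at larger amounts of compound and lower numbers for an effect already at smaller amounts: 100 mg/kg
compound 2, `CCOc1ccc(NC(=O)N/N=C(\C)CC(C)=O)cc1` — this assay: 100 mg/kg

Compound 2 stands level with compound 1 at the digits shown: the step from compound 1 to compound 2, with no change at the digits printed from compound 1 to compound 2 (within the scatter), lies within the scatter, so the two values are read as the same. Compound 3, `CCOc1ccc(NC(=O)N/N=C(\C)CC(C)C)cc1`, has not yet been measured in this assay. It differs from compound 2 in one place, with isopropyl in place of acetyl on a saturated chain carbon bound to a carbon with a double bond to nitrogen.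

Going by the values given here, only one measured step bears on this change, and it is the one just described, in which the group on the carbon with a double bond to nitrogen was exchanged without any change beyond the scatter. The exchange leading to compound 3 is cut one bond further out, where an acetyl gives way to an isopropyl. On that basis the step from compound 2 to compound 3 is expected to be no change at the digits printed from compound 2 to compound 3 (within the scatter), that is, no change beyond the scatter. Compound 3 is therefore estimated at 100 mg/kg, with a range from 50 mg/kg to 300 mg/kg.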

Compound 3, minimum effective dose: 100 mg/kg
For compound 3 middle estimate and measured number coincide at the digits printed; low and high end bracket the measured number.
By their numbers in this assay, from the lowest: compounds 1, 2 and 3 (each within the scatter of the next).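

In this assay, the exchange of acetyl for isopropyl on a saturated chain carbon bound to a carbon with a double bond to nitrogen gives no change at the digits printed from compound 2 to compound 3 (within the scatter). Acetyl counts a hydrogen-bond acceptor and a double bond outside aromatic rings, whereas isopropyl, of the same heavy-atom count, is all carbon and has neither, so this change in the outer part of the group is the first to show that the carbonyl of compound 2 is not needed to hold the value. Compared directly with the ring-bearing compound, isobutyl in place of 2-hydroxyphenyl gives no change at the digits printed from compound 1 to compound 3 (within the scatter), and no measurement is available here that would account for this sameness.

With all three compounds on one value, the compounds shown do not reveal whether any group at this place can move the minimum effective dose in either direction. On these data alone, it stays open whether an amine, a carboxylic acid or a longer chain in place of isobutyl would separate from these compounds in this assay, or whether the value would again stay within the scatter.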